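The compounds below may be only part of what the source reports. "The series", "measured", "known", "first", "only" and "open" are said of these compounds alone.

Measured in a functional assay on HeLa cells (Homo sapiens) for inhibition; on this read-out lower numbers stand for stronger inhibition and higher numbers for weaker inhibition:
compound 1 `CCN(C(=O)CC(CC(=O)NCCN1CCCCC1)c1ccc(Cl)cc1)C1Cc2ccccc2C1` gives 20400 nM
compound 2 `CCN(C(=O)CC(CC(=O)NCCN1CCCC1)c1ccc(Cl)cc1)C1Cc2ccccc2C1` gives 36400 nM
compound 3 `CCN(CC)CCNC(=O)CC(CC(=O)N(CC)C1Cc2ccccc2C1)c1ccc(Cl)cc1` gives 24300 nM

Compound 2 stands level with the other two, with a 1.8-fold higher number from compound 1 to compound 2 (0.25 log units; within the scatter) on one side and a 1.5-fold lower number from compound 2 to compound 3 (0.18 log units; within the scatter) on the other. Compound 4 `CCN(C(=O)CC(CC(=O)NCCN1CCCC1)c1ccccc1)C1Cc2ccccc2C1` carries hydrogen in place of chloro on an aromatic carbon, para to a large group, with hydrogen in place of chloro on an aromatic carbon as the whole difference from compound 2.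

All measured steps, these two and a 1.2-fold higher number from compound 1 to compound 3 (0.08 log units; within the scatter) as well, exchange only the piperidin-1-yl, pyrrolidin-1-yl and diethylamino groups on the chain. None of them tests the 4-chlorophenyl to phenyl change. From the compounds shown here alone, no step beyond the scatter is therefore expected in this assay in either direction, though this remains untested. The expected move is a 1.2-fold higher number from compound 2 to compound 4 (0.06 log units; within the scatter) at this estimate. For compound 4 the estimate is 42000 nM with an expected range from 18000 nM to 90000 nM on this read-out.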

Compound 4, half-maximal inhibitory concentration: > 100000 nM
Compound 4: no number, only a limit; the forecaster's own chance of this, stated with the estimate: 15%; at least 2.3-fold (0.37 log units) between middle value and limit.
By their numbers in this assay, from the lowest: compounds 1, 3 and 2 (each within the scatter of the next). At a limit, above all of these: compound 4.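

Of the steps shown, only this one lies beyond the scatter, and it is the only one that changes the aromatic ring rather than the amine on the chain: an at least 2.7-fold higher number from compound 2 to compound 4 (0.43 log units; beyond the scatter). In this assay, the chloro on the aromatic carbon, para to a large group, therefore matters to the read-out in the pyrrolidin-1-yl compounds. The size of the step remains unread, as the result for compound 4 is a limit and not a number: the limit of > 100000 nM in this assay, at which 1 of the 4 values shown sits.

From the compounds shown here alone, whether bromo, methoxy or trifluoromethyl at this position would match chloro remains open. So does whether the 4-chlorophenyl to phenyl change has the same effect on the piperidin-1-yl compound 1 and the diethylamino compound 3.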